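Reopening the ring on the amide carbonyl

A few compounds are considered here, and "the series" means these few. Any claim that something is new, unique, unknown or untested is made for them only; others in the source may bear on it.

Compound 1 `CC1CCC(C(=O)N2CC(c3nc(-c4cccc(Cl)c4)no3)C2)CC1`: 1500 nM
Compound 2 `O=C(C1CCC1)N1CC(c2nc(-c3cccc(Cl)c3)no2)C1`: a limit only, > 10000 nM

In an assay on HEK293 cells for positive allosteric modulation of metabotropic glutamate receptor 5 (Homo sapiens), read by FLIPR (a lower number here means that less compound is needed, a higher number that more compound is needed for the effect), compound 1 gives 1500 nM. For compound 2 the assay reports only a limit, > 10000 nM (the limit of > 10000 nM in this assay, at which 1 of the 2 values shown sits). Compound 3 `CC1CCN(C(=O)N2CC(c3nc(-c4cccc(Cl)c4)no3)C2)CC1` differs from compound 2 by 4-methylpiperidin-1-yl in place of cyclobutyl on a carbonyl carbon. Within the data shown here, the one measured step that bears on this is an at least 6.6-fold higher number from compound 1 to compound 2 (0.82 log units; beyond the scatter), where shrinking the ring to cyclobutyl raised the number. Restoring a six-membered non-aromatic ring carrying a methyl is expected to move the number back down, so the expected step is an at least 3.3-fold lower number from compound 2 to compound 3 (0.52 log units; beyond the scatter). Compound 3 is therefore estimated at 3000 nM, with a range from 800 nM to 15000 nM.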

Compound 3, half-maximal effective concentration: 865 nM
Compound 3: the middle estimate sits 3.5-fold (0.54 log units) above what was measured; low and high end bracket the measured number.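

Putting 4-methylpiperidin-1-yl in place of cyclobutyl on the carbonyl carbon gives an at least 11-fold lower number from compound 2 to compound 3 (1.06 log units; beyond the scatter), so at this position the size of the ring matters far more than the earlier pair alone could show. Compound 2 has a limit only: the limit of > 10000 nM in this assay, at which 1 of the 3 values shown sits. Swapping the ring carbon attached to the carbonyl for nitrogen gives a 1.7-fold lower number from compound 1 to compound 3 (0.24 log units; within the scatter), so the two methyl-bearing six-membered rings cannot be told apart. Still open, going by these compounds, is how an unsubstituted piperidin-1-yl or a morpholin-4-yl on the same carbonyl carbon would compare.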